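This account rests on a few compounds, and the source may have more. Where it says the series, first, only, none or still open, it means among the compounds named here.

Measured in a physicochemical assay for lipophilicity, at pH 7.4; on this read-out lower numbers stand for lower lipophilicity and higher numbers for higher lipophilicity:
- compound 1 `Cc1[nH]ncc1-c1nnc(-c2ccc(OC(C)C)c(Cl)c2)s1`: 5.45
- compound 2 `Cc1c(-c2nnc(-c3ccc(OC(C)C)c(Cl)c3)s2)cnn1CCC(=O)O`: 3.16

Compound 1 holds the higher of the two numbers in this assay, and compound 2 lies clearly beneath it. Compound 3 `CC(C)Oc1ccc(-c2nnc(-c3ccccc3)s2)cc1Cl` differs from compound 1 in one place: phenyl in place of 5-methyl-1H-pyrazol-4-yl on an aromatic carbon. Within the data shown here, the only measured step, a number 2.29 log units lower from compound 1 to compound 2 (beyond the scatter), is large, but it keeps the 5-methyl-1H-pyrazol-4-yl group and adds 2-carboxyethyl, so it bears on this change only indirectly. A moderate step to a higher number is therefore expected in this assay, beyond the scatter. The estimated step is a number 0.85 log units higher from compound 1 to compound 3 (beyond the scatter). For compound 3 the expected value is 6.3, with an estimated range of 5.6 to 7.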

Compound 3, distribution coefficient: 8.65
For compound 3 the middle estimate is 2.35 log units below the measured one, and the stated range ends below it.
By their numbers in this assay, from the lowest: compound 2; then compound 1; then compound 3.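

In this assay, replacing the group on this aromatic carbon itself gives a number 3.20 log units higher from compound 1 to compound 3 (beyond the scatter), so this position moves the read-out by a large step even with no added chain. Both groups hold 6 heavy atoms, so the step comes at an unchanged heavy-atom count, while the hydrogen-bond donor and acceptor of 5-methyl-1H-pyrazol-4-yl are lost. Nothing available explains the size of this step. On these data alone, it remains open whether a phenyl bearing an amine at this carbon would fall nearer compound 1 or compound 3.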